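A Chloromethylbenzyl Purine: Swapping Chloro for Amino

This account rests on a few compounds, and the source may have more. Where it says the series, first, only, none or still open, it means among the compounds named here.

Compound 1 `ClCc1ccccc1Cn1cnc2c(Cl)nc(Cl)nc21` belongs to a small group of three measured purines that carry a chloromethyl-substituted benzyl group. In a functional assay on SF-268 cells (Homo sapiens) for cytotoxicity, read by sulforhodamine B assay, with a stated time of 48 h (on this read-out lower numbers stand for stronger inhibition of growth and higher numbers for weaker inhibition of growth), compound 1 gives 4160 nM, the second highest of the three numbers. Compound 2 `ClCc1cccc(Cn2cnc3ncnc(Cl)c32)c1` gives 3460 nM in this assay, which lies within the usual scatter of the value of compound 1. Compound 3 `ClCc1ccccc1Cn1cnc2ncnc(Cl)c21` gives 24500 nM in this assay, a number well above that of compound 1, beyond the scatter.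

Compound 4 `Nc1nc(Cl)c2ncn(Cc3ccccc3CCl)c2n1` has not yet been measured. It differs from compound 1 in one place: amino in place of chloro on an aromatic carbon. Going by the values given here, no measured pair in this set shows this exchange, so no direct guide to its size exists. Given that compound 3, which shares the same benzyl group, gives a clearly higher number than compound 1, a modest weakening is expected, with the step from compound 1 to compound 4 estimated at a 1.9-fold higher number from compound 1 to compound 4 (0.28 log units; within the scatter). Compound 4 is therefore expected to give about 8000 nM in this assay, with a plausible range from 2500 nM to 25000 nM.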

Compound 4, concentration for total growth inhibition: 14500 nM
Beside the measured number, compound 4's estimate is 1.8-fold (0.26 log units) below it; low and high end bracket the measured number.
By their numbers in this assay, from the lowest: compounds 2 and 1 (each within the scatter of the next); then compounds 4 and 3 (each within the scatter of the next).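

On the aromatic carbon between two ring nitrogen atoms, the exchange of chloro for amino in this assay gives a 3.5-fold higher number from compound 1 to compound 4 (0.54 log units; beyond the scatter) and so shows that this position is sensitive to what it carries. Replacing one heavy atom with another is enough to move the number beyond the scatter, and the move is towards weaker inhibition of growth. The earlier compounds offered no measured step at a single place, and no measurement here accounts for this one.

As far as these compounds go, it remains open how other groups on this same carbon would compare with chloro and amino, such as methoxy, methylamino or a longer alkylamine. Also open, from the compounds shown here alone, is whether the chloro group that stays in compound 4 would tolerate the same exchange to amino.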